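Tetrazole series: aryl-amine tetrazoles, acid dissociation

The source may hold more compounds than are shown below. What is called first, only, known or untested is meant among the compounds shown, and "the series" means these compounds.

Measured compounds:
compound 1 `COc1ccc(N(Cc2nnn[nH]2)Cc2ccc(Cl)cc2Cl)cc1` 4.29
compound 2 `CCCCCCCCN(Cc1nnn[nH]1)c1ccccc1` 4.83
compound 3 `Fc1ccc(CN(Cc2nnn[nH]2)c2ccccc2)c(F)c1` 4.13

Compound 2 stands highest of the three numbers in a physicochemical assay for acid dissociation. Its nearest neighbour is compound 1, whose value sits lower by more than the scatter, and the furthest is compound 3, whose value sits lower still, also by more than the scatter. Both lower compounds carry a six-membered aromatic ring at the saturated chain carbon bound to the nitrogen on the aromatic ring, where compound 2 carries a heptyl chain.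

Compound 4 `Clc1ccccc1CN(Cc1nnn[nH]1)c1ccccc1` has not yet been measured. It differs from compound 2 in one place: 2-chlorophenyl in place of heptyl on a saturated chain carbon bound to a nitrogen on an aromatic ring.

Among the compounds with values here, no step between two measured compounds isolates this exact change. The comparison of compound 2 with compounds 1 and 3 nonetheless points the same way: the ring-bearing compounds give the lower numbers. The step from compound 2 to compound 4 is therefore expected to be downward and beyond the scatter, of about a number 0.53 log units lower from compound 2 to compound 4 (beyond the scatter) in this assay.

For compound 4 the expected value is 4.3, within a range from 4.05 to 4.55, placing it near compound 1 and compound 3 rather than compound 2.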

Compound 4, acid dissociation constant: 4.34
Compound 4: middle estimate off by 0.04 log units, on the low side; the measured number falls inside the stated range.
By their numbers in this assay, from the lowest: compounds 3, 1 and 4 (each within the scatter of the next); then compound 2.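

Within the data shown here, replacing heptyl with 2-chlorophenyl on a saturated chain carbon bound to a nitrogen on an aromatic ring gives the first single-change step in this assay, at a number 0.49 log units lower from compound 2 to compound 4 (beyond the scatter), so a shift at this position no longer has to be inferred from compounds that differ in more than one place. The two groups have the same heavy-atom count, with neither hydrogen-bond donors nor acceptors and no net charge, so the step goes with an open chain of seven carbons giving way to a chlorine-bearing six-membered aromatic ring and not with a change in any of these counts. The compounds shown offer no measurement that accounts for the step.

Going by these compounds, whether the step goes with the aromatic ring or with its chlorine remains open, and an unsubstituted phenyl group at this position would separate the two. The compounds shown also leave open how the value depends on chain length, as a butyl chain would test, and whether a carboxylic acid or an amine on the same carbon would move the value in the same direction.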